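Lengthening the Chain From Compound 2 to Compound 3

The source may hold more compounds than are shown below. What is called first, only, known or untested is meant among the compounds shown, and "the series" means these compounds.

Compound 1 `CCCc1cn(Cc2ccccc2)nn1` and compound 2 `CCCCCCCc1cn(Cc2ccccc2)nn1` share the same core and differ only in the length of a saturated chain. In an assay on isolated protein for inhibition of Aromatase (Homo sapiens), read by fluorescence and colorimetric assay, with a stated time of 30 min (a lower number here means a stronger inhibitor, a higher number a weaker inhibitor), compound 1 gives 12600 nM, and compound 2 gives 9530 nM. The step of a 1.3-fold lower number from compound 1 to compound 2 (0.12 log units; within the scatter) is small. Among the measured compounds shown here, compound 2 thus stands at one end of the two numbers so far, with compound 1 at the other, and the gap between them lies within the scatter, so the two cannot be told apart.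

Compound 3 `CCCCCCCCCCc1cn(Cc2ccccc2)nn1` carries the change propyl in place of hydrogen on a saturated chain carbon, seven bonds along the chain from an aromatic carbon. For the measured compounds named here, the only step that bears on it is the earlier chain extension, a 1.3-fold lower number from compound 1 to compound 2 (0.12 log units; within the scatter), which stayed within the scatter. A further lengthening of the same kind is therefore expected to move this assay little, if at all, in either direction. Compound 3 is expected to give about 8000 nM, with a likely range from 4000 nM to 16000 nM, which means an expected step of a 1.2-fold lower number from compound 2 to compound 3 (0.08 log units; within the scatter).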

Compound 3, half-maximal inhibitory concentration: 6400 nM
The estimate for compound 3 lay 1.3-fold (0.10 log units) above the measured number; low and high end bracket the measured number.
By their numbers in this assay, from the lowest: compounds 3, 2 and 1 (each within the scatter of the next).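

In this assay, propyl in place of hydrogen on a saturated chain carbon, seven bonds along the chain from an aromatic carbon, gives a 1.5-fold lower number from compound 2 to compound 3 (0.17 log units; within the scatter) and so adds a second extension that cannot be told from repeat-measurement noise. The wider comparison is new and more telling: taken end to end, the chain extension gives a 2.0-fold lower number from compound 1 to compound 3 (0.29 log units; within the scatter) and so, even across the full span of chains shown, the result stays within the scatter and compound 1, compound 2 and compound 3 cannot be separated in this test. No supporting measurement is available to explain this result.

Going by these compounds, it remains open whether a still longer chain would give a number that stands clearly apart from these three, or whether a chain ending in an amine or a carboxylic acid would do so. It is also open whether a branched chain at this position would behave like the straight chains shown here.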